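Cyclohexyl in place of octyl on the ring nitrogen

A few compounds are considered here, and "the series" means these few. Any claim that something is new, unique, unknown or untested is made for them only; others in the source may bear on it.

Compound 1 `CCCCCCCCn1cc(CO[C@H]2CC(=O)[C@@H]3OC[C@H]2O3)nn1` carries an octyl on an aromatic nitrogen of the five-membered aromatic ring with 3 nitrogen. In a functional assay on MDA-MB-231 cells (Homo sapiens) for cytotoxicity, read by MTT assay, with a stated time of 48 h (on this read-out lower numbers stand for stronger inhibition and higher numbers for weaker inhibition), compound 1 gives > 50000 nM, which is a limit of the assay and not a number (the limit of > 50000 nM in this assay, at which 1 of the 3 values shown sits). Compound 3 `COc1ccc(Cn2cc(CO[C@H]3CC(=O)[C@@H]4OC[C@H]3O4)nn2)cc1` differs from compound 1 by 4-methoxyphenyl in place of heptyl on a saturated chain carbon bound to an aromatic nitrogen, and in this assay compound 3 gives 34800 nM. The step of an at least 1.4-fold lower number from compound 1 to compound 3 (0.15 log units; that floor lies within the scatter) is thus only a floor and says little about direction. Among the compounds with values here, compound 2 `O=C1C[C@H](OCc2cn(-c3cccc4ccccc34)nn2)[C@H]2CO[C@@H]1O2` in this assay gives 21900 nM; no single-point step links it to compound 1.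

Compound 4 `O=C1C[C@H](OCc2cn(C3CCCCC3)nn2)[C@H]2CO[C@@H]1O2` is the next case: cyclohexyl in place of octyl on an aromatic nitrogen. Within the data shown here, no measured step covers a shortening of the chain on the ring nitrogen; the one change that bears on it, from compound 1 to compound 3, stayed within the scatter at its floor, and compound 1 itself stands only at a limit. No step beyond the scatter is therefore expected, and a limit again is as likely as a number. Compound 4 is expected near 50000 nM, between 20000 nM and 150000 nM. The expected step is a number no higher from compound 1 to compound 4 (the limit leaves the size open).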

Compound 4, half-maximal inhibitory concentration: 24300 nM
Estimate against measurement, compound 4: 2.1-fold (0.31 log units) above; measured number inside the range.
By their numbers in this assay, from the lowest: compounds 2, 4 and 3 (each within the scatter of the next). At a limit, above all of these: compound 1.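

Within the data shown here, the change from octyl to cyclohexyl on the aromatic nitrogen gives the first step that clears the usual scatter in this assay and reads as an at least 2.0-fold lower number from compound 1 to compound 4 (0.31 log units; beyond the scatter), so the group on this nitrogen can change the read-out. The earlier step, an at least 1.4-fold lower number from compound 1 to compound 3 (0.15 log units; that floor lies within the scatter), gave only a floor within the scatter and no direction, whereas this change gives a direction, towards a lower number with the ring of carbon only. Compound 1 stands at a limit and not at a number, so the step remains a floor and its full size stays unknown: the limit of > 50000 nM in this assay, at which 1 of the 4 values shown sits.

Octyl and cyclohexyl differ both in the ring and in the count of heavy atoms, so these compounds cannot separate the two, and an open hexyl chain on the same nitrogen would hold the count of heavy atoms equal to that of cyclohexyl without the ring. As far as these compounds go, how a group carrying an amine or a carboxylic acid on this nitrogen would read also stays open, as does any change to the shared core.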